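This account rests on a few compounds, and the source may have more. Where it says the series, first, only, none or still open, it means among the compounds named here.

Series notes. Compound 1 `O=[N+]([O-])c1ccc(CN2CCC(n3cc(CC(OCc4cc(-c5ccccc5)no4)c4ccc(Br)cc4)nn3)CC2)cc1` carries the plain phenyl on the shared core. In a functional assay on HCT-116 cells (Homo sapiens) for cytotoxicity, with a stated time of 48 h (a higher number here means a weaker inhibitor, a lower number a stronger inhibitor), compound 1 gives only a limit of the assay, > 25000 nM. Compound 2 `N#Cc1ccc(-c2cc(COC(Cc3cn(C4CCN(Cc5ccc([N+](=O)[O-])cc5)CC4)nn3)c3ccc(Br)cc3)on2)cc1` carries a 4-cyanophenyl there; in this assay compound 2 likewise gives only a limit, > 25000 nM. Compound 3 `N#Cc1cccc(-c2cc(COC(Cc3cn(C4CCN(Cc5ccc([N+](=O)[O-])cc5)CC4)nn3)c3ccc(Br)cc3)on2)c1` carries a 3-cyanophenyl; in this assay compound 3 also gives only a limit, > 25000 nM. Compound 3 thus stands on the same limit as the other two, (the limit of > 25000 nM in this assay, at which 3 of the 3 values shown sit), and the steps a step that the two limits leave unreadable from compound 1 to compound 2, a step that the two limits leave unreadable from compound 1 to compound 3 and a step that the two limits leave unreadable from compound 2 to compound 3 cannot be sized. Compound 4 `COc1ccccc1-c1cc(COC(Cc2cn(C3CCN(Cc4ccc([N+](=O)[O-])cc4)CC3)nn2)c2ccc(Br)cc2)on1` is not yet measured; its change from compound 3 is 2-methoxyphenyl in place of 3-cyanophenyl on an aromatic carbon. For the measured compounds named here, no measured step gives a readable size, so no step beyond the scatter is anticipated in this assay; the estimated step is a step that the limit leaves unreadable from compound 3 to compound 4. Compound 4 is expected in this assay at 40000 nM, range 10000 nM to 200000 nM, most likely again as a limit only.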

Compound 4, half-maximal inhibitory concentration: > 25000 nM
Compound 4 gave a limit, no number; the forecaster's own chance of this, stated with the estimate: 85%; the middle value is on the limit's open side.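

No step can be read among compound 1, compound 2, compound 3 and compound 4, because each gives only a limit in this assay: the limit of > 25000 nM in this assay, at which 4 of the 4 values shown sit. The compounds shown leave open whether the plain phenyl, 4-cyanophenyl, 3-cyanophenyl and 2-methoxyphenyl differ at all in this assay.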